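A few compounds are considered here, and "the series" means these few. Any claim that something is new, unique, unknown or untested is made for them only; others in the source may bear on it.

Compound 1 `O=C(Nc1cccnc1)c1ccncc1`, compound 2 `O=C(Nc1cccnc1)c1ccc(Cl)cc1` and compound 3 `O=C(Nc1cccnc1)c1ccc(OC(F)(F)F)cc1` share one core and differ only in the group carried on an aromatic carbon of a six-membered aromatic ring of carbon only. In an assay on V79 cells for inhibition of cytochrome P450 11B1, mitochondrial (Homo sapiens), tested at 500 nM (on this read-out lower numbers stand for less inhibition and higher numbers for more inhibition at the one concentration tested (going by the name of the read-out)), compound 1 gives 4%, compound 2 gives 5% and compound 3 gives 3%; all three numbers lie within the usual scatter of one another, so none can be told apart on this read-out.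

Compound 4 `Cc1ccc(C(=O)Nc2cccnc2)cc1` has not been measured. It differs from compound 3 in one place: methyl in place of trifluoromethoxy on an aromatic carbon. Among the measured compounds shown here, the one measured step at this same place, a number 2 percentage points lower from compound 2 to compound 3 (within the scatter), moved the number by less than the scatter, and every compound with a group on that aromatic carbon sits at the same low level. The bearing of that step on the change to methyl is therefore that no step beyond the scatter is expected in this assay, in either direction.

Compound 4 is accordingly expected to give 4%, with a range from 0% to 12%, which is an expected step of a number 1 percentage points higher from compound 3 to compound 4 (within the scatter).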

Compound 4, a percentage reported as inhibition, at one concentration (the size of the read-out at that concentration, not a potency): 0%
For compound 4 the middle estimate is 4 percentage points above the measured one, within the range that was stated.
By their numbers in this assay, from the lowest: compounds 4, 3, 1 and 2 (each within the scatter of the next).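

In this assay the change from trifluoromethoxy to methyl gives a number 3 percentage points lower from compound 3 to compound 4 (within the scatter) and the change from chloro to methyl gives a number 5 percentage points lower from compound 2 to compound 4 (within the scatter) so neither change can be told apart from repeat-to-repeat variation. The earlier step compared only chloro with trifluoromethoxy, whereas methyl brings in a group of 1 heavy atom with no hydrogen-bond acceptor in place of one of 5 heavy atoms with 1 such acceptor, and the number on this aromatic carbon still shows no step beyond the scatter. No measurement at hand offers an explanation for this flat result.

Going by these compounds, whether an amine, a carboxylic acid or a longer chain on this aromatic carbon would move the number beyond the scatter stays open. Also open, on these data alone, is whether chloro, trifluoromethoxy and methyl would still look alike at another concentration.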